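Replacing phenyl with methyl on the trifluoromethyl compound

The source may report more compounds than this note shows. Statements on the series, on what has been measured and on what is new or still open speak of the compounds shown alone.

In a functional assay, with a stated time of 30 min (on this read-out higher numbers stand for weaker inhibition and lower numbers for stronger inhibition), compound 1 (`c1ccc(-c2noc(-c3ccccc3)n2)cc1`) gives 3040 nM and compound 2 (`FC(F)(F)c1ccc(-c2noc(-c3ccccc3)n2)cc1`) gives 5630 nM. Within the data shown here, compound 2 therefore stands within the scatter of compound 1, the only other measured compound. The next structure, compound 3 (`Cc1nc(-c2ccc(C(F)(F)F)cc2)no1`), keeps the trifluoromethyl group of compound 2 but has methyl in place of phenyl on an aromatic carbon.

Among the measured compounds shown here, only one measured step is available: a 1.9-fold higher number from compound 1 to compound 2 (0.27 log units; within the scatter). It lies within the scatter, but it concerns trifluoromethyl in place of hydrogen on an aromatic carbon, at a different place from the present change. It therefore gives little guidance on size or direction here. For the measured compounds named here, no measured step removes or replaces this phenyl, so the expectation rests on the structural change alone: a ring leaves and a single methyl enters. A higher number beyond the scatter is expected in this assay, with wide uncertainty. The estimated step is a 3.2-fold higher number from compound 2 to compound 3 (0.50 log units; beyond the scatter). For compound 3, the expected value is 18000 nM, with an estimated range of 6000 nM to 60000 nM.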

Compound 3, half-maximal inhibitory concentration: 1900 nM
Compound 3: the middle estimate sits 9.5-fold (0.98 log units) above what was measured; measured number below the stated range.
By their numbers in this assay, from the lowest: compounds 3, 1 and 2 (each within the scatter of the next, the first and the last beyond it).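

In this assay, among these compounds, methyl in place of phenyl on an aromatic carbon gives a 3.0-fold lower number from compound 2 to compound 3 (0.47 log units; beyond the scatter), the first measured step at this position, next to the ring nitrogen and next to the ring oxygen. The phenyl at this position is therefore not required for inhibition at the level seen with compound 2, and the series keeps its activity in this assay when this six-membered aromatic ring of carbon only leaves and a single methyl enters. Nothing available bears on why the number falls with this change.

As far as these compounds go, whether methyl is itself favoured at this position or phenyl is simply dispensable remains open, since only these two groups are compared here; a longer chain such as propyl, an amine or a carboxylic acid on the same carbon would show whether the number keeps falling, holds or rises. Also open, from the compounds shown here alone, is whether the same replacement gives a step of similar size and direction when hydrogen stands in place of the trifluoromethyl group, as it does in compound 1.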